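Series at the assay limit: the step to compound 4

A few compounds are considered here, and "the series" means these few. Any claim that something is new, unique, unknown or untested is made for them only; others in the source may bear on it.

Compound 1 `Nc1ccccc1NC(=O)CCCNCC(=O)Nc1cccc(Cl)c1`: > 100000 nM, a limit
Compound 2 `Nc1ccccc1NC(=O)CCCNCC(=O)Nc1ccc(Cl)cc1`: > 100000 nM, a limit
Compound 3 `Nc1ccccc1NC(=O)CCCNCC(=O)Nc1ccc(Br)cc1`: > 100000 nM, a limit

All three readings come from a functional assay on U-251 cells (Homo sapiens) for inhibition, read by MTT assay, with a stated time of 2 days; on this read-out lower numbers stand for higher toxicity in this test and higher numbers for lower toxicity in this test. Compound 3 has no number on this read-out, only a limit. The other two compounds sit at the same limit, as the limit of > 100000 nM in this assay, at which 3 of the 3 values shown sit, records.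

The next change leads to compound 4 `Nc1ccccc1NC(=O)CCCNCC(=O)Nc1cccc([N+](=O)[O-])c1`, with 3-nitrophenyl in place of 4-bromophenyl on an amide-type nitrogen.

Three measured steps change the group at this same place: a step that the two limits leave unreadable from compound 1 to compound 2, a step that the two limits leave unreadable from compound 1 to compound 3 and a step that the two limits leave unreadable from compound 2 to compound 3. None of them has a readable size, so they give no measure for the new change and no direction. Within the data shown here, no measured compound carries 3-nitrophenyl.

Among the measured compounds shown here, no step of readable size is therefore expected in this assay, and another report at the limit is the likeliest outcome. The estimated change is a number no higher from compound 3 to compound 4 (the limit leaves the size open), and this rests only on the shared limit in the limit of > 100000 nM in this assay, at which 3 of the 3 values shown sit. For compound 4 the estimated value is 100000 nM, with an expected range from 40000 nM to 200000 nM.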

Compound 4, concentration lethal to 50% of the cells: > 100000 nM
Compound 4 ended at the assay's limit; the forecaster's own chance of this, stated with the estimate: 85%; the middle value sits exactly at the limit.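

In this assay compound 4 gives > 100000 nM, a limit and not a number. Its steps from compound 1, compound 2 and compound 3 cannot be read, since all four compounds share one limit: the limit of > 100000 nM in this assay, at which 4 of the 4 values shown sit. The compounds shown leave open how far they differ in this test, and whether any group on this amide-type nitrogen gives a readable value.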